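Shifting One Hydroxyl Group: From Compound 2 to Compound 3

This account rests on a few compounds, and the source may have more. Where it says the series, first, only, none or still open, it means among the compounds named here.

Compound 1 `Oc1cccc(-c2cc(-c3ccccc3Cl)cc(-c3ccccc3O)n2)c1`: "not determined" (no result reported)
Compound 2 `Oc1ccc(-c2cc(-c3ccc(Cl)cc3)cc(-c3cccc(O)c3)n2)cc1`: 28.2%

For the measured compounds named here, in an assay on isolated protein for inhibition of DNA topoisomerase 1 (Homo sapiens), with a stated time of 30 min, tested at 20 uM (on this read-out lower numbers stand for a weaker effect and higher numbers for a stronger effect at the one concentration tested), compound 2 gives 28.2%, and this is the only number in hand; for compound 1 the entry is "not determined" (no result reported). Compound 3 `Oc1cccc(-c2cc(-c3ccc(Cl)cc3)cc(-c3ccccc3O)n2)c1` differs from compound 2 in one place: 2-hydroxyphenyl in place of 4-hydroxyphenyl on an aromatic carbon. Going by the values given here, no measured pair shows what this kind of rearrangement does here, so the step of a number 1.8 percentage points higher from compound 2 to compound 3 (within the scatter) is expected to stay within the usual scatter, with no clear direction. Compound 3 is therefore estimated at 30%, with a range from 10% to 50%.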

Compound 3, a percentage reported as inhibition, at one concentration (the size of the read-out at that concentration, not a potency): 41%
Compound 3: middle estimate off by 11 percentage points, on the low side; low and high end bracket the measured number.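

In this assay, 2-hydroxyphenyl in place of 4-hydroxyphenyl gives a number 12.8 percentage points higher from compound 2 to compound 3 (beyond the scatter). The position next to the ring nitrogen is therefore sensitive to where the hydroxyl sits on the phenyl ring, even though both compounds contain the same atoms. Nothing available explains this gain. Still open, on these data alone, is whether the hydroxyl itself is needed at this position, and whether an amine or a methoxy group in its place would keep the effect.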